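Swapping the Cyclopentyl Group in a Thromboxane Synthase Series

The source may hold more compounds than are shown below. What is called first, only, known or untested is meant among the compounds shown, and "the series" means these compounds.

Compound 1: `O=c1c2ccccc2c(-c2cccnc2)nn1C1CCCC1` — 97%
Compound 2: `CCOC(=O)Cn1nc(-c2cccnc2)c2ccccc2c1=O` — 28%

In an assay on isolated protein (Oryctolagus cuniculus) with Thromboxane-A synthase (Homo sapiens) as the target, tested at 1 uM (a lower number here means less inhibition, a higher number more inhibition at the concentration tested (going by the name of the read-out)), compound 1 gives 97%, the highest of the two numbers recorded; the nearest is compound 2 with 28%. Within the data shown here, the only measured step is a number 69 percentage points lower from compound 1 to compound 2 (beyond the scatter), a large loss that accompanies the exchange of the cyclopentyl on the aromatic nitrogen for a short chain bearing a polar group.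

Compound 3, `NCCn1nc(-c2cccnc2)c2ccccc2c1=O`, is not yet measured. It differs from compound 1 by 2-aminoethyl in place of cyclopentyl on an aromatic nitrogen. The step from compound 1 to compound 2 bears directly on this case, since in both the cyclopentyl on the aromatic nitrogen is replaced by a small open chain, and that step was large and downward. On this single precedent a clear drop is expected, though the two entering chains are different, so the size is uncertain: the step from compound 1 to compound 3 is estimated at a number 52 percentage points lower from compound 1 to compound 3 (beyond the scatter). Compound 3 is therefore expected to give about 45%, with a likely range from 15% to 80%.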

Compound 3, a percentage reported as inhibition, at one concentration (the size of the read-out at that concentration, not a potency): 29%
Estimate against measurement, compound 3: 16 percentage points above, within the range that was stated.
By their numbers in this assay, from the lowest: compounds 2 and 3 (each within the scatter of the next); then compound 1.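

In this assay, a second open chain on the aromatic nitrogen brings a loss of the same kind as the first (a number 68 percentage points lower from compound 1 to compound 3 (beyond the scatter)), so the large drop does not belong to the ethoxycarbonyl group alone. Aminomethyl in place of ethoxycarbonyl on the saturated chain carbon bound to the aromatic nitrogen leaves the two compounds indistinguishable (a number 1 percentage points higher from compound 2 to compound 3 (within the scatter)), so at this position these two quite different chain ends give the same picture, and among the three compounds only the one with cyclopentyl keeps the high number. Nothing measured here accounts for how far both chains fall short of cyclopentyl.

As far as these compounds go, what remains open is whether the loss follows from giving up the carbon ring or from bringing a heteroatom into the group, a question that a plain pentyl chain or a cyclohexyl ring on the same nitrogen could help to settle. From the compounds shown here alone, it is equally open whether a carboxylic acid at the chain end, or a longer chain carrying the amine, would stay at the same low level.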